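Swapping the Aryl Group on a Shared Core

The compounds below may be only part of what the source reports. "The series", "measured", "known", "first", "only" and "open" are said of these compounds alone.

Measured in a functional assay (muscle tissue) with Cavia porcellus as the target; on this read-out lower numbers stand for an effect already at smaller amounts and higher numbers for an effect only at larger amounts of compound:
- Compound 1 `COC(=O)C1=C(C)N=C(C)/C(=C(\O)OC)C1c1ccc(Cl)cc1`: 8130 nM
- Compound 2 `COC(=O)C1=C(C)N=C(C)/C(=C(\O)OC)C1c1ccccc1Br`: 7.59 nM
- Compound 3 `COC(=O)C1=C(C)N=C(C)/C(=C(\O)OC)C1c1cccc(C#N)c1`: 34.7 nM

Compound 3, at 34.7 nM, sits in the middle of these three numbers, much closer to compound 2 than to compound 1. Within the data shown here, the next compound changes only one group. On a saturated ring carbon of the shared core, compound 4 `COC(=O)C1=C(C)N=C(C)/C(=C(\O)OC)C1c1cc(C)ccc1C` carries 2,5-dimethylphenyl in place of 3-cyanophenyl on a saturated ring carbon.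

Among the measured compounds shown here, three measured steps bear on this change. Two large ones both leave 4-chlorophenyl: a 1100-fold lower number from compound 1 to compound 2 (3.03 log units; beyond the scatter) and a 230-fold lower number from compound 1 to compound 3 (2.37 log units; beyond the scatter). The third, between the remaining groups, is only modest: a 4.6-fold higher number from compound 2 to compound 3 (0.66 log units; beyond the scatter). Like 2-bromophenyl and 3-cyanophenyl, the entering 2,5-dimethylphenyl has no group at the 4 of 4-chlorophenyl. For the measured compounds named here, compound 4 is therefore expected to fall with compound 2 and compound 3, not with compound 1, although three compounds are a thin basis and no measured compound carries methyl groups on this aryl ring. No step beyond the scatter is expected in this assay, in either direction. The expected change is a 1.2-fold lower number from compound 3 to compound 4 (0.06 log units; within the scatter). Compound 4 is estimated at 30 nM, with an expected range from 5 nM to 200 nM.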

Compound 4, half-maximal effective concentration: 100 nM
The estimate for compound 4 lay 3.3-fold (0.52 log units) below the measured number, and the stated range covers the measured number.
By their numbers in this assay, from the lowest: compound 2; then compound 3; then compound 4; then compound 1.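

In this assay, an aryl ring carrying only methyl groups gives a 2.9-fold higher number from compound 3 to compound 4 (0.46 log units; beyond the scatter), so the nitrile and its hydrogen-bond acceptor can be replaced at a modest cost, yet this step still lies beyond the usual scatter. The same ring gives a 13-fold higher number from compound 2 to compound 4 (1.12 log units; beyond the scatter) and an 81-fold lower number from compound 1 to compound 4 (1.91 log units; beyond the scatter), which shows two things: the 2-bromophenyl, 3-cyanophenyl and 2,5-dimethylphenyl compounds all stay well below the 4-chlorophenyl compound, and they also differ clearly among themselves, so this position responds to more than one contrast between these aryl groups. No measurement at hand explains why these aryl groups give such different numbers.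

Compound 4 carries both methyl groups at once, so the compounds shown do not reveal what either would do alone, as in 2-methylphenyl or 3-methylphenyl. From the compounds shown here alone, how an amine or a carboxylic acid on this aryl ring would read out also remains open, as does a longer chain on the saturated ring carbon in place of the aryl ring.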